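The source may hold more compounds than are shown below. What is called first, only, known or untested is meant among the compounds shown, and "the series" means these compounds.

Of the compounds shown here, two have been measured so far. Compound 1 `O=C1Nc2cc(F)ccc2C1CCCCN1CCN(c2ccc(Cl)cc2)CC1` and compound 2 `O=C1Nc2ccccc2C1CCCCN1CCN(c2ccccn2)CC1` share most of their skeleton but differ from each other in more than one place. In an assay on membranes from frontal cortex for displacement of a labelled ligand from Adrenergic receptor alpha-1 (Rattus norvegicus), read by scintillation counting, with a stated time of 45 min (a higher number here means a weaker inhibitor, a lower number a stronger inhibitor), compound 1 gives 55 nM. In this assay compound 2 gives 130 nM, which is the higher of the two numbers and lies beyond the usual scatter from compound 1. Compound 2 and compound 1 differ in two places at once. The gap between them cannot be tied to a single structural change.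

Compound 3 `O=C1Nc2cc(F)ccc2C1CCCCN1CCN(c2ccccn2)CC1` has not yet been measured. It differs from compound 2 in one place only: fluoro in place of hydrogen on an aromatic carbon of the shared core. Among the measured compounds shown here, compound 1 carries this same fluoro, but also another change elsewhere, so no measured pair shows the fluoro on its own. The expectation is therefore a modest step toward a lower number, possibly none beyond the scatter. Compound 3 is expected to give about 100 nM, within a range of 40 nM to 250 nM. The estimated step of a 1.3-fold lower number from compound 2 to compound 3 (0.11 log units; within the scatter) is expected to stay within the usual scatter.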

Compound 3, inhibition constant: 33 nM
Compound 3: the middle estimate sits 3.0-fold (0.48 log units) above what was measured; measured number below the stated range.
By their numbers in this assay, from the lowest: compounds 3 and 1 (each within the scatter of the next); then compound 2.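

In this assay the fluoro on an aromatic carbon of the shared core can now be read on its own, and this single heavy atom in place of hydrogen gives a 3.9-fold lower number from compound 2 to compound 3 (0.60 log units; beyond the scatter) on a core that otherwise stays the same. The other single change now readable, pyridin-2-yl in place of 4-chlorophenyl on an amine nitrogen in a ring, gives a 1.7-fold lower number from compound 1 to compound 3 (0.22 log units; within the scatter) and so leaves these two groups not told apart when the fluoro is present, which makes the fluoro the only one of the two single changes with a step beyond the scatter. Nothing available on these compounds accounts for the size of the fluoro step.

Among the compounds shown here, the fluoro step is seen only with pyridin-2-yl on the ring nitrogen, so it remains open whether it would be of similar size with 4-chlorophenyl there. Also open, going by these compounds, is how a chloro or a methoxy group would read in place of the fluoro at this carbon, how the fluoro would read on another carbon of the same ring, and what a shorter or longer chain would do.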